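The source may hold more compounds than are shown below. What is called first, only, known or untested is meant among the compounds shown, and "the series" means these compounds.

Compound 1 `CCC(CC)Nc1ncnc2c1ncn2C1O[C@H](CO)[C@@H](O)[C@H]1O` gives 0.75 nM in an assay on cell membranes for binding affinity to adenosine receptor A1 (Cavia porcellus), read by radioligand binding; on this read-out lower numbers stand for stronger inhibition and higher numbers for weaker inhibition. Compound 2 `CCCn1c(=O)c2nc(C(O)(CC)CC)[nH]c2n(CCC)c1=O` gives 170 nM in this assay, the highest of the three numbers; its nearest neighbour is compound 3 `CCCn1c(=O)c2nc(-c3cccn3C)[nH]c2n(CCC)c1=O`, which gives 140 nM, while compound 1 lies furthest away. The step of a 1.2-fold lower number from compound 2 to compound 3 (0.08 log units; within the scatter) exchanges one group for another on the same aromatic carbon of the shared core and stays within the scatter. Compound 4 `CCCn1c(=O)c2nc(C(C)(C)C)[nH]c2n(CCC)c1=O` differs from compound 2 by tert-butyl in place of 1-ethyl-1-hydroxypropyl on an aromatic carbon. Going by the values given here, no measured step puts tert-butyl in place of 1-ethyl-1-hydroxypropyl, and the one step at this carbon was flat. Compound 4 is therefore expected to move only modestly, a 1.9-fold lower number from compound 2 to compound 4 (0.28 log units; within the scatter), with an estimated 90 nM and a range from 30 nM to 300 nM.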

Compound 4, inhibition constant: 31 nM
Beside the measured number, compound 4's estimate is 2.9-fold (0.46 log units) above it; the measured number falls inside the stated range.
By their numbers in this assay, from the lowest: compound 1; then compound 4; then compounds 3 and 2 (each within the scatter of the next).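

Going by these compounds alone, the aromatic carbon between two ring nitrogen atoms, flat in the one earlier step, proves sensitive to the group it carries: tert-butyl lowers the number against both earlier groups (a 5.5-fold lower number from compound 2 to compound 4 (0.74 log units; beyond the scatter); a 4.5-fold lower number from compound 3 to compound 4 (0.65 log units; beyond the scatter)). Neither the 1-ethyl-1-hydroxypropyl group nor the 1-methyl-1H-pyrrol-2-yl group matches tert-butyl here, so this position can separate these groups. No evidence at hand explains the shift. The compounds shown leave open whether a methyl group or a longer chain at this carbon would lower the number further. They also leave open how an amine would fare there.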